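Swapping the Ester of Compound 1 for a Methyl

The source may hold more compounds than are shown below. What is called first, only, known or untested is meant among the compounds shown, and "the series" means these compounds.

Compound 1 `CCOC(=O)c1ccc(/N=N/N(C)C(=O)[C@H](C)NC(C)=O)cc1` carries an ethoxycarbonyl group on its aromatic ring. In a physicochemical assay for metabolic stability, read by HPLC, in phosphate buffer, at pH 7.7 (on this read-out higher numbers stand for a longer-lived compound and lower numbers for a shorter-lived compound), compound 1 gives 15.7 h; compound 2 `CCC(=O)N[C@@H](C)C(=O)N(C)/N=N/c1ccc(C#N)cc1` gives 10.1 h and compound 3 `C[C@H](NC(=O)c1ccccc1)C(=O)N(C)/N=N/c1ccc(C#N)cc1` gives 9.2 h, both within the scatter of the number for compound 1. For the measured compounds named here, the only measured step, a 1.1-fold lower number from compound 2 to compound 3 (0.04 log units; within the scatter), changes the group on a carbonyl carbon at the other end of the shared core and is within the scatter. Compound 4 `CC(=O)N[C@@H](C)C(=O)N(C)/N=N/c1ccc(C)cc1` differs from compound 1 by methyl in place of ethoxycarbonyl on an aromatic carbon. Going by the values given here, no measured step touches this aromatic position; the only evidence is that compound 1, compound 2 and compound 3, with different groups there, all lie within the scatter of one another. One therefore expects no step beyond the scatter, a 1.3-fold lower number from compound 1 to compound 4 (0.12 log units; within the scatter). For compound 4 the estimated half-life is 12 h, between 6 h and 24 h.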

Compound 4, half-life: 46.5 h
Beside the measured number, compound 4's estimate is 3.9-fold (0.59 log units) below it; the measured number lies above the stated range.
By their numbers in this assay, from the lowest: compounds 3, 2 and 1 (each within the scatter of the next); then compound 4.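

Methyl in place of ethoxycarbonyl on an aromatic carbon gives a 3.0-fold higher number from compound 1 to compound 4 (0.47 log units; beyond the scatter) in this assay and so shows that this position can move the half-life. For the compounds shown here, the earlier compounds could not show this, since the only earlier step, a 1.1-fold lower number from compound 2 to compound 3 (0.04 log units; within the scatter) at a carbonyl carbon, stayed within the scatter and none touched this aromatic position. Nothing measured here accounts for the rise. The compounds shown leave open whether the longer half-life is specific to methyl. A chlorine atom, an amine or a carboxylic acid at this position could still give a different result.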